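From 4-hydroxybenzyl to 2-hydroxyphenyl on the amide

A few compounds are considered here, and "the series" means these few. Any claim that something is new, unique, unknown or untested is made for them only; others in the source may bear on it.

For the measured compounds named here, in a functional assay on PC-3 cells (Homo sapiens) for inhibition, read by MTT assay (a higher number here means a weaker inhibitor of growth, a lower number a stronger inhibitor of growth), compound 2 `CC1=C(/C=C/C(C)=C/C=C/C(C)=C\C(=O)NCc2ccc(O)cc2)C(C)(C)CCC1n1ccnc1` gives 3540 nM, the lower of the two numbers so far, and compound 1 `CC1=C(/C=C/C(C)=C/C=C/C(C)=C\C(=O)Nc2ccccc2)C(C)(C)CCC1n1ccnc1` gives 8910 nM. Compound 3 `CC1=C(/C=C/C(C)=C/C=C/C(C)=C\C(=O)Nc2ccccc2O)C(C)(C)CCC1n1ccnc1` carries 2-hydroxyphenyl in place of 4-hydroxybenzyl on an amide-type nitrogen. Going by the values given here, the only measured step, a 2.5-fold lower number from compound 1 to compound 2 (0.40 log units; beyond the scatter), is modest and bears only in part. Compound 3 resembles compound 1 in its ring on that nitrogen and compound 2 in its hydroxy group, so it should fall between them. Only a small rise, within the scatter, is expected, estimated as a 1.4-fold higher number from compound 2 to compound 3 (0.15 log units; within the scatter). The estimated value for compound 3 is 5000 nM, with a range of 2000 nM to 12000 nM.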

Compound 3, concentration for 50% growth inhibition: 15500 nM
Estimate against measurement, compound 3: 3.1-fold (0.49 log units) below; measured number outside the range, above it.
By their numbers in this assay, from the lowest: compound 2; then compounds 1 and 3 (each within the scatter of the next).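

In this assay, hydroxy in place of hydrogen on the aromatic ring of compound 1 gives a 1.7-fold higher number from compound 1 to compound 3 (0.24 log units; within the scatter), so on a ring bonded directly to the amide-type nitrogen, this hydroxy group does not bring the lower number of compound 2. The change to 2-hydroxyphenyl from 4-hydroxybenzyl gives a 4.4-fold higher number from compound 2 to compound 3 (0.64 log units; beyond the scatter), which shows that a hydroxyphenyl-type group alone is not enough to retain that number. No measurement available here accounts for this difference.

Still open, as far as these compounds go, is how plain benzyl and 4-hydroxyphenyl on that nitrogen would read. Those two groups would separate the contribution of the carbon link from that of the hydroxy group's ring position.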